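From Hydroxy to Methylamino in an Antiproliferative Series

The compounds below may be only part of what the source reports. "The series", "measured", "known", "first", "only" and "open" are said of these compounds alone.

Measured in a functional assay on A2780 cells (Homo sapiens) for antiproliferative activity, read by MTT assay, with a stated time of 48 h; on this read-out lower numbers stand for stronger inhibition and higher numbers for weaker inhibition 
- compound 1 (`C=C(c1cc(OC)c(OC)c(OC)c1)c1ccc(OC)cc1NC(=O)CO`): 30 nM 
- compound 2 (`COc1ccc(C(=O)c2cc(OC)c(OC)c(OC)c2)c(NC(=O)CN(C)C)c1`): 580 nM 
- compound 3 (`C=C(c1ccc(OC)cc1NC(=O)CNC)c1ccc(OC)c2c1C=CC(C)(C)O2`): 720 nM 

Compound 1 holds the lowest number of the three, which on this read-out means the strongest inhibition. The numbers of compound 2 and compound 3 both lie above it, well beyond the usual scatter.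

Compound 4 (`C=C(c1cc(OC)c(OC)c(OC)c1)c1ccc(OC)cc1NC(=O)CNC`) keeps the core of compound 1 and alters a single group: methylamino in place of hydroxy on a saturated chain carbon bound to a carbonyl carbon. Going by the values given here, no measured pair isolates this swap, so its size cannot be read directly from the data. The closest hint is compound 3, which carries the same methylamino group on a different core and gives 720 nM in this assay as its number. Since the core differs as well, that value sets no firm size for the swap, and only a cautious expectation is possible. A moderate rise in the number, toward weaker inhibition, is expected, with a 2.3-fold higher number from compound 1 to compound 4 (0.37 log units; beyond the scatter) as the estimated step. Compound 4 is estimated at 70 nM with 15 nM to 350 nM as the expected range.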

Compound 4, half-maximal inhibitory concentration: 140 nM
The estimate for compound 4 lay 2.0-fold (0.30 log units) below the measured number, within the range that was stated.
By their numbers in this assay, from the lowest: compound 1; then compound 4; then compounds 2 and 3 (each within the scatter of the next).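

Put into the core of compound 1 with nothing else altered, methylamino in place of hydroxy on a saturated chain carbon bound to a carbonyl carbon gives, in this assay, a 4.7-fold higher number from compound 1 to compound 4 (0.67 log units; beyond the scatter). Going by these compounds alone, this is the first direct reading of the swap: the position tolerates the change with a modest weakening, and compound 4 at 140 nM keeps a number in the nanomolar range. The group that leaves and the group that enters each count 1 hydrogen-bond donor and 1 hydrogen-bond acceptor with no net charge, so the step appears even with those counts level, and nothing at hand gives a cause for it.

The compounds shown leave open how a plain amino group, a carboxylic acid or a longer chain ending in an amine would compare at this same place on the core of compound 1. They also leave open whether the swap from hydroxy to methylamino would give a step of similar size on any other core, as this single pair is the only one that isolates it.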